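Swapping an aromatic ring for a non-aromatic one

The compounds below may be only part of what the source reports. "The series", "measured", "known", "first", "only" and "open" are said of these compounds alone.

Three close relatives of one shared core have been tested in a functional assay on cells (Melanoma cell, Homo sapiens) for cytotoxicity, read by sulforhodamine B assay, with a stated time of 48 h; on this read-out lower numbers stand for stronger inhibition of growth and higher numbers for weaker inhibition of growth. Compound 1 `COc1ccc(OC)c(-c2cc(-c3ccccc3)nn2-c2ccc(S(N)(=O)=O)cc2)c1` gives 40800 nM. Compound 2 `COc1ccc(OC)c(-c2cc(-c3ccccc3)nn2-c2ccc(S(=O)(=O)NC(C)=O)cc2)c1` gives 36200 nM, and compound 3 `COc1ccc(OC)c(-c2cc(-c3ccc(Cl)cc3)nn2-c2ccc(S(=O)(=O)NC(C)=O)cc2)c1` gives 28700 nM. On these three numbers compound 2 stands second highest: its nearest neighbour is compound 1, and the change a 1.1-fold lower number from compound 1 to compound 2 (0.05 log units; within the scatter) stays inside the scatter, as does the change a 1.3-fold lower number from compound 2 to compound 3 (0.10 log units; within the scatter) that leads on to compound 3.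

Compound 4 `CC(=O)NS(=O)(=O)c1ccc(-n2nc(-c3ccccc3)cc2C2=CC(=O)C=CC2=O)cc1` has not yet been measured. It differs from compound 2 in one place: a group of 8 heavy atoms (6 carbon, 2 oxygen; one six-membered non-aromatic ring of carbon only) in place of a group of 10 heavy atoms (8 carbon, 2 oxygen; one six-membered aromatic ring of carbon only), on an aromatic carbon. Neither measured step bears directly on this change. The step from compound 1 to compound 2 touched the sulfonamide nitrogen, and the step from compound 2 to compound 3 touched an aromatic carbon of the phenyl group; both were inside the scatter, and both left the 2,5-dimethoxyphenyl group untouched. Nothing in the data shows how this assay answers to a change on the five-membered aromatic ring itself. The expectation for compound 4 therefore rests on compound 2 alone, with a wide range: an estimated step of a 1.4-fold lower number from compound 2 to compound 4 (0.16 log units; within the scatter), meaning an expected value of 25000 nM for compound 4, between 6000 nM and 70000 nM.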

Compound 4, concentration for total growth inhibition: 100000 nM
Beside the measured number, compound 4's estimate is 4.0-fold (0.60 log units) below it; measured number above the stated range.
By their numbers in this assay, from the lowest: compounds 3, 2 and 1 (each within the scatter of the next); then compound 4.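

In this assay, putting the non-aromatic ring in place of the 2,5-dimethoxyphenyl group gives a 2.8-fold higher number from compound 2 to compound 4 (0.44 log units; beyond the scatter), a modest loss of growth inhibition. For the compounds shown here, this is the first step in the set to lie beyond the scatter, whereas the changes on the sulfonamide nitrogen and on the phenyl group both stayed within it, so the read-out does respond to a change at this position, on the aromatic carbon next to the ring nitrogen. The two groups match in hydrogen-bond donors, hydrogen-bond acceptors and net charge, so those counts do not separate them, and no measurement here accounts for the rise in the number.

This single swap changes the ring and removes both methoxy groups at once, so it leaves open which of these matters; a plain phenyl group or a 2,5-dihydroxyphenyl group at the same place would help pull the two apart. It also leaves open whether a chloro group on the phenyl group, as in compound 3, would have any effect alongside the non-aromatic ring of compound 4.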